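Swapping a Methylated Aromatic Group for Naphthalen-2-yl

A few compounds are considered here, and "the series" means these few. Any claim that something is new, unique, unknown or untested is made for them only; others in the source may bear on it.

Measured in a functional assay on HCT-116 cells (Homo sapiens) for inhibition, read by MTT assay, with a stated time of 72 h; on this read-out lower numbers stand for stronger inhibition and higher numbers for weaker inhibition:
- compound 1 `O=C1/C(=C\c2ccccc2)c2c(ncn2COCc2ccccc2)CCN1Cc1ccccc1`: 20000 nM
- compound 2 `Cc1cccc(CN2CCc3ncn(COCc4ccccc4)c3/C(=C/c3ccccc3)C2=O)c1`: 3800 nM
- compound 3 `O=C1/C(=C\c2ccc(C(F)(F)F)cc2)c2c(ncn2COCc2ccccc2)CCN1Cc1ccccc1`: 36000 nM

Of these three, compound 2 gives the lowest number, 3800 nM. Compound 4 `O=C1/C(=C\c2ccccc2)c2c(ncn2COCc2ccccc2)CCN1Cc1ccc2ccccc2c1` departs from compound 2 at a single place: naphthalen-2-yl in place of 3-methylphenyl on a saturated chain carbon bound to an amide-type nitrogen in a ring. Naphthalen-2-yl stands in place of 3-methylphenyl on a saturated chain carbon bound to an amide-type nitrogen in a ring.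

Two measured steps are available. The more relevant one is a 5.3-fold lower number from compound 1 to compound 2 (0.72 log units; beyond the scatter), a modest gain in this assay that came with a methyl in place of hydrogen on an aromatic carbon. That methyl leaves with the 3-methylphenyl group in compound 4. The other, a 1.8-fold higher number from compound 1 to compound 3 (0.26 log units; within the scatter), stays within the scatter and involves trifluoromethyl on a different aromatic ring, so it says little here. Among the compounds with values here, no measured step shows how a naphthalen-2-yl group behaves, and the larger aromatic group could either keep or lose the gain seen with compound 2. No clear direction can therefore be argued, and no step beyond the scatter is expected. The estimate is a 1.3-fold higher number from compound 2 to compound 4 (0.12 log units; within the scatter). Compound 4 is expected at about 5000 nM, within an estimated range of 1500 nM to 18000 nM.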

Compound 4, half-maximal inhibitory concentration: 19400 nM
Beside the measured number, compound 4's estimate is 3.9-fold (0.59 log units) below it; the measured number lies above the stated range.
By their numbers in this assay, from the lowest: compound 2; then compounds 4, 1 and 3 (each within the scatter of the next).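

In this assay, exchanging 3-methylphenyl for naphthalen-2-yl gives a 5.1-fold higher number from compound 2 to compound 4 (0.71 log units; beyond the scatter) and so does not keep the gain seen with the methyl group, a modest loss at this place on a saturated chain carbon bound to an amide-type nitrogen in a ring. Set against the plain phenyl group, naphthalen-2-yl gives a 1.0-fold lower number from compound 1 to compound 4 (0.01 log units; within the scatter) and cannot be told apart from it, so among the three groups shown here only 3-methylphenyl stands out from the others, and the larger aromatic group with its second ring brings no gain of its own. Nothing available accounts for why the methylated ring and the naphthalene ring part ways in this assay.

The compounds shown leave open whether the gain belongs to the methyl group specifically or would also appear with a methoxy group, a chlorine or an amine on the same phenyl ring. They also do not show how a longer chain between the ring nitrogen and the aromatic group, or a carboxylic acid on that group, would read out at this position.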